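Adding a Second Chloro Group to a Two-Ring Core

The source may report more compounds than this note shows. Statements on the series, on what has been measured and on what is new or still open speak of the compounds shown alone.

Of the compounds shown here, three have so far been tested in a functional assay on UACC-257 cells (Homo sapiens) for cytotoxicity, read by sulforhodamine B assay, with a stated time of 48 h; on this read-out lower numbers stand for stronger inhibition of growth and higher numbers for weaker inhibition of growth. Compound 1 `ClCc1ccccc1Cn1cnc2c(Cl)nc(Cl)nc21` gives 1820 nM in this assay. Compound 2 `ClCc1ccccc1Cn1cnc2c(Cl)ncnc21` carries one chloro group fewer and gives 10700 nM in this assay. The change from compound 2 to compound 1 is chloro in place of hydrogen on an aromatic carbon, and it produced a 5.9-fold lower number from compound 2 to compound 1 (0.77 log units; beyond the scatter). Compound 3 `ClCc1cccc(Cn2cnc3c(Cl)ncnc32)c1` is made of the same atoms as compound 2 joined differently; the difference between the two cores is not broken down here. In this assay compound 3 gives 20400 nM, a value within the scatter of that of compound 2.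

Compound 4 `ClCc1cccc(Cn2cnc3c(Cl)nc(Cl)nc32)c1` has not yet been measured. Among the measured compounds shown here, it arises from compound 3 by chloro in place of hydrogen on an aromatic carbon, which is the same change as the one from compound 2 to compound 1, made at the same place. The earlier step, a 5.9-fold lower number from compound 2 to compound 1 (0.77 log units; beyond the scatter), is the only basis for an expectation here. On that basis a step of about a 5.4-fold lower number from compound 3 to compound 4 (0.73 log units; beyond the scatter) is expected. Compound 4 is therefore estimated to give about 3800 nM in this assay, with a likely range from 1500 nM to 9500 nM.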

Compound 4, concentration for 50% growth inhibition: 1860 nM
Compound 4: middle estimate off by 2.0-fold (0.31 log units), on the high side; low and high end bracket the measured number.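

Adding a chloro group on the aromatic carbon between two ring nitrogen atoms gave an 11-fold lower number from compound 3 to compound 4 (1.04 log units; beyond the scatter) in this assay, so the change lowered the number on this core as it did on the core of compound 2. The sizes of the two steps cannot be told apart, which means the change carried over from one core to the other without a measurable loss or gain: the same change on two cores in this assay, a 5.9-fold lower number (0.77 log units; beyond the scatter) from compound 2 to compound 1 and an 11-fold lower number (1.04 log units; beyond the scatter) from compound 3 to compound 4, 1.9-fold (0.27 log units) apart, within the scatter of two such steps. Among the compounds shown here, this rests on only two pairs of compounds, so it shows that the step transfers between these two cores, but it does not show that it would transfer to any other core, and it does not explain why the chloro group lowers the number.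

The compounds shown leave open whether a different group at this same place, such as an amine, a methoxy group or a fluoro group, would lower the number as well. They also leave open whether the same step would appear in cells of another kind.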